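Swapping the aromatic group on a compound at the assay limit

The source may hold more compounds than are shown below. What is called first, only, known or untested is meant among the compounds shown, and "the series" means these compounds.

Compounds measured so far in a functional assay on A549 cells (Homo sapiens) for antiproliferative activity, read by MTT assay, with a stated time of 72 h; a higher number here means a weaker inhibitor, a lower number a stronger inhibitor:
- compound 1 `COc1cc2ncnc(Nc3ccc(Cl)cc3Cl)c2cc1OCCCN1CCNCCNCCNCC1` gives 23800 nM
- compound 2 `COc1cccc(Nc2ncnc3cc(OC)c(OCCCN4CCNCCNCC4)cc23)c1` gives > 50000 nM, which is a limit
- compound 3 `COc1cc2ncnc(Nc3cccc(F)c3)c2cc1OCCCN1CCNCCNCC1` gives > 50000 nM, which is a limit

Compound 3 has no exact number of its own, only the limit > 50000 nM in this assay. Compound 2 shares that position, as the limit of > 50000 nM in this assay, at which 2 of the 3 values shown sit, shows. Only compound 1 has an exact value.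

The next compound, compound 4 `COc1cc2ncnc(Nc3ccc(Cl)cc3Cl)c2cc1OCCCN1CCNCCNCC1`, has 2,4-dichlorophenyl in place of 3-fluorophenyl on a nitrogen on an aromatic ring. The counted difference is 2,4-dichlorophenyl in place of 3-fluorophenyl on a nitrogen on an aromatic ring.

Among the compounds with values here, the one measured step, a step that the two limits leave unreadable from compound 2 to compound 3, gives no size to carry over, as both of its ends are limits. The better guide is compound 1, which carries the same 2,4-dichlorophenyl group and gives 23800 nM in this assay. It differs from compound 4 elsewhere in its structure, so this guide is loose.

A move to a lower number, meaning a stronger inhibitor, is therefore expected, and the estimated change is an at least 2.2-fold lower number from compound 3 to compound 4 (0.35 log units; beyond the scatter), although compound 4 could still end up as a limit. For compound 4 the estimated value is 22000 nM, with an expected range from 9000 nM to 50000 nM.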

Compound 4, half-maximal inhibitory concentration: 44200 nM
Beside the measured number, compound 4's estimate is 2.0-fold (0.30 log units) below it, within the range that was stated.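

In this assay, putting 2,4-dichlorophenyl on the nitrogen gives the nine-membered ring series an exact value rather than a limit, which yields an at least 1.1-fold lower number from compound 3 to compound 4 (0.05 log units; that floor lies within the scatter) and an at least 1.1-fold lower number from compound 2 to compound 4 (0.05 log units; that floor lies within the scatter). Both steps are only floors that lie within the scatter, so they do not show how much the aromatic group matters, and the true gaps cannot be read from them: the limit of > 50000 nM in this assay, at which 2 of the 4 values shown sit. With 2,4-dichlorophenyl held fixed, the ring on the side chain can also be compared, and a 1.9-fold higher number from compound 1 to compound 4 (0.27 log units; within the scatter) means that the two rings cannot be told apart in this assay.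

From the compounds shown here alone, it remains open whether one chlorine alone would give the same result, as a 4-chlorophenyl or a 2-chlorophenyl group on the nitrogen would test, since 2,4-dichlorophenyl carries two chlorines at once. Also open, going by these compounds, is whether a simple piperazine ring or a longer chain in place of the large ring would move the number beyond the scatter.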